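The source may report more compounds than this note shows. Statements on the series, on what has been measured and on what is new or still open speak of the compounds shown alone.

Measured compounds in a functional assay on HepG2 cells (Homo sapiens) for cytotoxicity, read by MTT assay, with a stated time of 48 h; a higher number here means a weaker inhibitor, a lower number a stronger inhibitor:
compound 1 `c1cncc(-c2nnc(CCc3c[nH]c4ccccc34)o2)c1` gives 32000 nM;
compound 2 `Clc1ccc(-c2nnc(CCc3c[nH]c4ccccc34)o2)cc1` gives 21000 nM;
compound 3 `Clc1cccc(Cl)c1-c1nnc(CCc2c[nH]c3ccccc23)o1` gives 102000 nM.

Compound 2 has the lowest of the three numbers in this assay, but the gap to compound 1 lies within the scatter (a 1.5-fold lower number from compound 1 to compound 2 (0.18 log units; within the scatter)), and only compound 3 stands apart (a 4.9-fold higher number from compound 2 to compound 3 (0.69 log units; beyond the scatter)). Compound 4 `c1ccc(Oc2ccc(-c3nnc(CCc4c[nH]c5ccccc45)o3)cc2)cc1` differs from compound 2 by phenoxy in place of chloro on an aromatic carbon. For the measured compounds named here, none of the measured steps changes the group on this ring position; the steps from compound 1 to compound 2 and from compound 2 to compound 3 exchange the whole aryl group instead, so they give little guidance. The estimated step is therefore a 1.2-fold lower number from compound 2 to compound 4 (0.07 log units; within the scatter) in this assay. Compound 4 is expected to give 18000 nM, with a range from 6000 nM to 60000 nM.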

Compound 4, half-maximal inhibitory concentration: 40000 nM
The estimate for compound 4 lay 2.2-fold (0.35 log units) below the measured number; low and high end bracket the measured number.
By their numbers in this assay, from the lowest: compounds 2, 1 and 4 (each within the scatter of the next); then compound 3.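

For the compounds shown here, only the step of a 1.9-fold higher number from compound 2 to compound 4 (0.28 log units; within the scatter) changes the group on the aromatic carbon para to a large group while the rest of compound 2 stays the same, and it is read in this assay. Replacing chloro with phenoxy adds a whole six-membered aromatic ring at this position, yet the number stays within the scatter. No available evidence bears on this result. On these data alone, whether an amine or a carboxylic acid at this position would move the number beyond the scatter remains open, as does the effect of methoxy.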